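A few compounds are considered here, and "the series" means these few. Any claim that something is new, unique, unknown or untested is made for them only; others in the source may bear on it.

Measured in a functional assay on the whole organism with Scenedesmus acutus as the target, with a stated time of 20 h; a lower number here means a stronger inhibitor, a higher number a weaker inhibitor:
Compound 1 `CCCOC(=O)c1cc(N2C(=O)C3=C(CCCC3)C2=O)c(F)cc1Cl`: 66.1 nM
Compound 2 `CCCOC(=O)c1cc(N2C(=O)C3=C(CCCC3)C2=O)ccc1Cl`: 661 nM

Compound 2 holds the higher of these two numbers, so it is the weaker inhibitor. Compound 3 `C#CCOc1cc(N2C(=O)C3=C(CCCC3)C2=O)ccc1Cl` differs from it with propargyloxy in place of propoxycarbonyl on an aromatic carbon, ortho to a chloro group: propargyloxy in place of propoxycarbonyl on an aromatic carbon. For the measured compounds named here, the only measured step, a 10-fold higher number from compound 1 to compound 2 (1.00 log units; beyond the scatter), is hydrogen in place of fluoro, a different change, so it gives no direct measure of this one. In this assay, no step beyond the scatter is therefore expected, though with wide uncertainty. The expected step is a 1.7-fold lower number from compound 2 to compound 3 (0.22 log units; within the scatter). The estimate for compound 3 is 400 nM, with an expected range of 80 nM to 2000 nM.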

Compound 3, half-maximal inhibitory concentration: 537 nM
Compound 3: middle estimate off by 1.3-fold (0.13 log units), on the low side; the range from low to high includes it.
By their numbers in this assay, from the lowest: compound 1; then compounds 3 and 2 (each within the scatter of the next).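

In this assay, propargyloxy in place of propoxycarbonyl, ortho to a chloro group, gives a 1.2-fold lower number from compound 2 to compound 3 (0.09 log units; within the scatter). The earlier step concerned only a fluoro group; this one shows that the propoxycarbonyl group at this position can be exchanged for propargyloxy with no step beyond the scatter. No measurement here accounts for the two groups reading alike. On these data alone, it remains open whether propargyloxy would give the same result alongside the fluoro group of compound 1. As far as these compounds go, how an amine, a carboxylic acid or a longer chain would read at this position also remains open.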